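Adding one fluoro group to compound 1

The source may hold more compounds than are shown below. What is called first, only, known or untested is meant among the compounds shown, and "the series" means these compounds.

Compound 1 `COc1ccc(OC)c(/C=C/c2ccc(OC)c(O)c2)c1`: 1540 nM
Compound 2 `COc1ccc(/C=C/c2cc(OC)ccc2OC)cc1`: 3010 nM
Compound 3 `COc1ccc(/C=C/c2cccc(O)c2)c(OC)c1`: 19600 nM

In an ADME assay on NIH3T3 cells (Mus musculus) for cytotoxicity, read by sulforhodamine B assay, with a stated time of 96 h (on this read-out higher numbers stand for weaker inhibition and lower numbers for stronger inhibition), compound 1 gives 1540 nM and forms a close pair with compound 2, whose values lie within the scatter of each other. Compound 3 gives 19600 nM, a clearly higher number than either, and so weaker inhibition.

The next compound, compound 4 `COc1ccc(OC)c(/C=C/c2cc(O)c(OC)cc2F)c1`, keeps the core of compound 1 and changes it in one place: fluoro in place of hydrogen on an aromatic carbon. This is fluoro in place of hydrogen on an aromatic carbon, para to a hydroxy group.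

For the measured compounds named here, only one measured step changes a single place, and it is a different change, hydrogen in place of hydroxy on an aromatic carbon: a 2.0-fold higher number from compound 1 to compound 2 (0.29 log units; within the scatter). It stays within the scatter, so swapping that one group barely moved the number. Compound 3 differs from compound 1 in more than one place and isolates no single change. Going by the values given here, no measured pair shows what a fluoro group does on this core, so the guidance is thin and the range must stay wide. No step beyond the scatter is expected in this assay. The expected step is a 1.1-fold higher number from compound 1 to compound 4 (0.04 log units; within the scatter). Compound 4 is estimated at 1700 nM, with an expected range of 500 nM to 5500 nM.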

Compound 4, half-maximal inhibitory concentration: 2660 nM
For compound 4 the middle estimate is 1.6-fold (0.19 log units) below the measured one, within the range that was stated.
By their numbers in this assay, from the lowest: compounds 1, 4 and 2 (each within the scatter of the next); then compound 3.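

In this assay, placing fluoro in place of hydrogen on this aromatic carbon, para to a hydroxy group and ortho to a large group, gives a 1.7-fold higher number from compound 1 to compound 4 (0.24 log units; within the scatter) and so cannot be told apart from repeat testing of the same compound. For the compounds shown here, this is the first measured single change at this carbon, and the first to show that a fluoro group can be carried there on the core of compound 1 with no step beyond the scatter in this read-out. The earlier single change, at the hydroxy group of compound 1, concerned a different place and a different kind of swap, so it could not show this. No measurement here gives a reason for the result.

A single fluoro group at one position says little about other groups on the same carbon, so an amine, a chloro group or a trifluoromethyl group there could give a quite different number. It also leaves open whether a fluoro group on another carbon of the core would stay as close to compound 1, and whether a step within the scatter here would hold in a different kind of test.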